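A few compounds are considered here, and "the series" means these few. Any claim that something is new, unique, unknown or untested is made for them only; others in the source may bear on it.

Three compounds share one core and differ only in the group carried on an amine nitrogen in a ring of a six-membered non-aromatic ring with 2 nitrogen. In a functional assay on HT-29 cells (Homo sapiens) for cytotoxicity, read by MTT assay, with a stated time of 24 h, tested at 0.64 ug/mL (a lower number here means a weaker effect, a higher number a stronger effect of the compound at the concentration tested), compound 3 `Cn1c(-c2ccc(NC(=O)CN3CCN(c4ccccc4)CC3)cc2)nc(-c2ccccc2)c1-c1ccccc1` gives 17.3%. Compound 1 `CCN1CCN(CC(=O)Nc2ccc(-c3nc(-c4ccccc4)c(-c4ccccc4)n3C)cc2)CC1` gives 7.4% in this assay, and compound 2 `CN(C)/C=C/N1CCN(CC(=O)Nc2ccc(-c3nc(-c4ccccc4)c(-c4ccccc4)n3C)cc2)CC1` gives 3.1%. The steps among them are a number 9.9 percentage points higher from compound 1 to compound 3 (within the scatter), a number 14.2 percentage points higher from compound 2 to compound 3 (beyond the scatter) and a number 4.3 percentage points lower from compound 1 to compound 2 (within the scatter). Compound 3 thus has the highest of the three numbers, set apart from compound 2 but not from compound 1.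

Compound 4 `Cn1c(-c2ccc(NC(=O)CN3CCN(Cc4ccccc4)CC3)cc2)nc(-c2ccccc2)c1-c1ccccc1` follows from compound 3 by one change: benzyl in place of phenyl on an amine nitrogen in a ring. Among the measured compounds shown here, no measured step tests benzyl itself. The two steps that end at compound 3 show that exchanging the group on this ring nitrogen moved this assay only modestly at most: a number 9.9 percentage points higher from compound 1 to compound 3 (within the scatter) and a number 14.2 percentage points higher from compound 2 to compound 3 (beyond the scatter). Since benzyl keeps the aromatic ring of phenyl and adds one carbon, the expectation for compound 4 is a step of a number 5.3 percentage points lower from compound 3 to compound 4 (within the scatter), which lies within the scatter. Compound 4 is therefore estimated at 12% in this assay, with a range from 3% to 23%.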

Compound 4, a percentage reported as activity, at one concentration (the size of the read-out at that concentration, not a potency): 15.5%
The estimate for compound 4 lay 3.5 percentage points below the measured number, within the range that was stated.
By their numbers in this assay, from the lowest: compounds 2, 1, 4 and 3 (each within the scatter of the next, the first and the last beyond it).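

Replacing phenyl with benzyl on the ring nitrogen adds one carbon and keeps the aromatic ring, and in this assay this gives a number 1.8 percentage points lower from compound 3 to compound 4 (within the scatter), so the two groups cannot be told apart here. Replacing 2-(dimethylamino)ethenyl with benzyl gives a number 12.4 percentage points higher from compound 2 to compound 4 (beyond the scatter), whereas the change from ethyl to benzyl gives a number 8.1 percentage points higher from compound 1 to compound 4 (within the scatter), so compounds 3 and 4 share the same standing: each is set apart from compound 2 but not from compound 1. No supporting data bear on what lies behind these numbers.

The compounds shown leave open how far this tolerance extends, for instance whether a longer chain such as phenylethyl, or a carboxylic acid carried on the ring nitrogen, would stay within the scatter of benzyl. Since each number comes from a single concentration, they also leave open whether compounds with such similar read-outs would still match across a range of concentrations.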